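One Chloro Change on Two Cores, Measured and Expected

The source may hold more compounds than are shown below. What is called first, only, known or untested is meant among the compounds shown, and "the series" means these compounds.

Measured so far in a functional assay on SiHa cells (Homo sapiens) for cytotoxicity; a higher number here means a weaker inhibitor, a lower number a stronger inhibitor:
Compound 1, `O=[N+]([O-])c1ccc2[nH]cc(C(c3ccccc3)c3cc4ccccc4o3)c2c1`, gives 40400 nM.
Compound 2, `O=[N+]([O-])c1ccc2[nH]cc(C(c3ccccc3)c3cc4cc(Cl)ccc4o3)c2c1`, gives only a limit of the assay, > 100000 nM.
Compound 3, `Cc1c(C(c2ccccc2)c2cc3ccccc3o2)[nH]c2ccccc12`, gives only a limit of the assay, > 100000 nM.

Compound 2 differs from compound 1 in one place: chloro in place of hydrogen on an aromatic carbon. The measured step is an at least 2.4-fold higher number from compound 1 to compound 2 (0.39 log units; beyond the scatter), a shift towards weaker inhibition, with compound 2 sitting at the limit of the assay.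

Compound 3 carries a different core. The difference between the two cores is not broken down here.

Compound 4, `Cc1c(C(c2ccccc2)c2cc3cc(Cl)ccc3o2)[nH]c2ccccc12`, has not yet been measured in this assay. It arises from compound 3 by chloro in place of hydrogen on an aromatic carbon. This is the same change as that made from compound 1 to compound 2, at a place described in the same words.

For compound 4 the step expected is a step that the limit leaves unreadable from compound 3 to compound 4. That expectation rests on the measured step of an at least 2.4-fold higher number from compound 1 to compound 2 (0.39 log units; beyond the scatter), and on compound 3 already sitting at the limit of > 100000 nM in this assay, at which 2 of the 3 values shown sit. Among the measured compounds shown here, since the one measured instance of this change moved the number upward and the starting point is already a limit, a value below that limit would be surprising. Compound 4 is therefore expected to give about 250000 nM, within a range from 100000 nM to 1000000 nM, and most likely to be reported only as a limit rather than a number.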

Compound 4, half-maximal inhibitory concentration: 77900 nM
Compound 4: middle estimate off by 3.2-fold (0.51 log units), on the high side; measured number below the stated range.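

In this assay, chloro in place of hydrogen on an aromatic carbon gives an at least 1.2-fold lower number from compound 3 to compound 4 (0.10 log units; that floor lies within the scatter), a step whose direction runs against the rise seen on the core of compound 1. Set side by side, the two steps show that this change did not carry over from one core to the other with the same result: the same change on two cores in this assay, an at least 2.4-fold higher number (0.39 log units; beyond the scatter) from compound 1 to compound 2 and an at least 1.2-fold lower number (0.10 log units; that floor lies within the scatter) from compound 3 to compound 4, at least 3.1-fold (0.50 log units) apart, beyond the scatter of two such steps. This shows that, for these two pairs, the result of the change cannot simply be transferred between the cores, but it does not show why they part, and compound 2 and compound 3 are each reported only as a limit, so neither step has a known full size: the limit of > 100000 nM in this assay, at which 2 of the 4 values shown sit.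

The compounds shown leave open whether another group at the same place, such as fluoro, methoxy or an amine, would also give different results on the two cores. They also leave open which feature of the two cores goes with the difference, and whether a third core would follow the pair of compound 1 and compound 2 or the pair of compound 3 and compound 4.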